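The compounds below may be only part of what the source reports. "The series", "measured", "known", "first", "only" and "open" are said of these compounds alone.

For the measured compounds named here, in an ADME assay on the whole organism (Rattus norvegicus, strain Sprague-Dawley) for pharmacokinetics, using cassette dosing, at a dose of 0.5 mg/kg by the intravenous route (on this read-out higher numbers stand for fast clearance and lower numbers for slow clearance), compound 1 `O=C(Nc1ccc2[nH]c(=O)oc2c1)C(=O)N1CCN(c2ccc(Cl)cc2)CC1` gives 7.2 mL/min/kg and this is the only number available so far. For compound 2 `O=C(Nc1ccc2[nH]c(=O)oc2c1)C(=O)N1CCN(c2ccccc2)CC1` the entry reads "not determined" (no result reported) and so offers nothing to compare. Going by the values given here, compound 1 therefore has no rank among its neighbours and no measured step to lean on. Compound 3 `C[C@@H]1CN(c2ccc(Cl)cc2)CCN1C(=O)C(=O)Nc1ccc2[nH]c(=O)oc2c1` differs from compound 1 by methyl in place of hydrogen on a saturated ring carbon and has yet to be measured. Among the compounds with values here, no measured pair shows what such a change does in this assay and so no move beyond the usual scatter is expected in either direction. The estimated step (a 1.0-fold lower number from compound 1 to compound 3 (0.01 log units; within the scatter)) stays within that scatter. For compound 3 the estimated clearance is 7 mL/min/kg with an expected range of 3.5 mL/min/kg to 15 mL/min/kg around it.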

Compound 3, clearance: 5.4 mL/min/kg
The estimate for compound 3 lay 1.3-fold (0.11 log units) above the measured number; the measured number falls inside the stated range.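

For the compounds shown here, the first measured pair for this change shows that, in this assay, methyl in place of hydrogen on a saturated ring carbon, next to the ring nitrogen, gives a 1.3-fold lower number from compound 1 to compound 3 (0.12 log units; within the scatter) and so stays inside the usual scatter of repeated measurements. At this position, then, the added methyl leaves the clearance of the core of compound 1 indistinguishable from that of compound 3 on this read-out. Nothing available explains the result.

As far as these compounds go, whether a longer chain such as ethyl, or a hydroxymethyl group or an amine, on the same carbon would also stay within the scatter remains open. So does the effect of methyl on the ring carbons two ring bonds from the ring nitrogen, or of the opposite configuration at this carbon.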